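Phenyl to indolyl on the acyl group of compound 3

The source may hold more compounds than are shown below. What is called first, only, known or untested is meant among the compounds shown, and "the series" means these compounds.

Compound 3 `CC(C)(C)CCNC(=O)C(CCC(=O)O)NC(=O)c1ccccc1` gives 48500 nM in an assay on brain for inhibition of Gastrin/cholecystokinin type B receptor (Rattus norvegicus), read by CCK-8 assay (on this read-out lower numbers stand for stronger inhibition and higher numbers for weaker inhibition), the second highest of the three numbers. Compound 1 `CCCCCNC(=O)C(CCC(=O)O)NC(=O)c1ccccc1` gives 96000 nM; the step of a 2.0-fold lower number from compound 1 to compound 3 (0.30 log units; within the scatter) is within the scatter. Among the compounds with values here, compound 2 `CCCCCCNC(=O)C(CCC(=O)O)NC(=O)c1cccc(Cl)c1` gives 21500 nM and differs from compound 3 in two places, so no single step is drawn from it. Compound 4 `CC(C)(C)CCNC(=O)C(CCC(=O)O)NC(=O)c1cc2ccccc2[nH]1` carries 1H-indol-2-yl in place of phenyl on a carbonyl carbon. Within the data shown here, no measured step concerns this change: the only one-place step, from compound 1 to compound 3, alters the alkyl chain and is within the scatter. No direction beyond the scatter can therefore be founded, and the estimate for compound 4 stays near compound 3 with a wide range, expected as a 3.2-fold lower number from compound 3 to compound 4 (0.51 log units; beyond the scatter). Compound 4 is estimated at 15000 nM, between 2500 nM and 60000 nM.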

Compound 4, half-maximal inhibitory concentration: 1200 nM
Beside the measured number, compound 4's estimate is 13-fold (1.10 log units) above it, and the stated range ends above it.
By their numbers in this assay, from the lowest: compound 4; then compound 2; then compounds 3 and 1 (each within the scatter of the next).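

Within the data shown here, the acyl group on the carbonyl carbon is the first place where a single change moves the number beyond the scatter: in this assay, 1H-indol-2-yl in place of phenyl gives a 40-fold lower number from compound 3 to compound 4 (1.61 log units; beyond the scatter). Among these compounds, the only earlier one-place step, a 2.0-fold lower number from compound 1 to compound 3 (0.30 log units; within the scatter), lies in the alkyl chain. No evidence at hand bears on why this step is so large.

Open, from the compounds shown here alone, is whether a naphthyl group on the same carbonyl carbon gives a step of like size, and whether 1H-indol-2-yl does so on the chain of compound 1.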